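The source may report more compounds than this note shows. Statements on the series, on what has been measured and on what is new or still open speak of the compounds shown alone.

Measured in an ADME assay on LLC-MK2 cells (Macaca mulatta) for cytotoxicity, read by spectrophotometry and crystal violet staining, with a stated time of 4 days; on this read-out higher numbers stand for lower toxicity in this test and lower numbers for higher toxicity in this test:
- Compound 1 `CC(C)n1ncc2c(C(=O)Nc3cccc(S(=O)(=O)N(C)C)c3)cc(-c3cccs3)nc21`: > 200000 nM (a limit)
- Compound 2 `CC(C)n1ncc2c(C(=O)Nc3ccccc3S(N)(=O)=O)cc(-c3cccs3)nc21`: 25000 nM

The value of compound 1 is a limit of this assay, not a number. Among the measured compounds shown here, compound 2, at 25000 nM, holds the only actual number so far, so it has no measured neighbour to be ranked against. Compound 3 `CC(C)n1ncc2c(C(=O)Nc3cccc(S(N)(=O)=O)c3)cc(-c3cccs3)nc21` carries 3-sulfamoylphenyl in place of 2-sulfamoylphenyl on an amide-type nitrogen. A modest move towards lower toxicity in this assay is expected, a 2.4-fold higher number from compound 2 to compound 3 (0.38 log units; beyond the scatter). This expectation leans on compound 1, which reads > 200000 nM, a limit. Compound 3 is estimated at 60000 nM, with an expected range of 20000 nM to 200000 nM.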

Compound 3, half-maximal cytotoxic concentration: 25000 nM
For compound 3 the middle estimate is 2.4-fold (0.38 log units) above the measured one; the measured number falls inside the stated range.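

In this assay, 3-sulfamoylphenyl in place of 2-sulfamoylphenyl on the amide-type nitrogen gives no change at the digits printed from compound 2 to compound 3 (within the scatter), so the two placements of the sulfamoyl group read alike. The change that counts among these compounds lies on the sulfonyl sulfur instead, where amino in place of dimethylamino gives an at least 8.0-fold lower number from compound 1 to compound 3 (0.90 log units; beyond the scatter). The value of compound 1 is a limit of this assay, not a number: the limit of > 200000 nM in this assay, at which 1 of the 3 values shown sits.

From the compounds shown here alone, it remains open how methylamino on the sulfonyl sulfur would read in this assay, with one methyl rather than two. Also open, going by these compounds, is how a carboxylic acid in place of the sulfamoyl group would read.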